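This account rests on a few compounds, and the source may have more. Where it says the series, first, only, none or still open, it means among the compounds named here.

Compound 1 `CC(=O)c1ccc(OC(=O)/C=C/c2cccc(F)c2)cc1` and compound 2 `CC(=O)c1ccc(OC(=O)/C=C/c2ccc(F)c(F)c2)cc1` share one core, while compound 3 `CC(=O)c1ccc(O[C@@H]2O[C@H](COC(=O)/C=C/c3cccc(F)c3)[C@@H](O)[C@H](O)[C@H]2O)cc1` and compound 4 `CC(=O)c1ccc(O[C@@H]2O[C@H](COC(=O)/C=C/c3ccc(F)c(F)c3)[C@@H](O)[C@H](O)[C@H]2O)cc1` share a larger one. The difference between the two cores is not broken down here. Compound 1 turns into compound 2 by fluoro in place of hydrogen on an aromatic carbon, and compound 3 turns into compound 4 by fluoro in place of hydrogen on an aromatic carbon, the same change at the same kind of place.

In an ADME assay on HepG2 2.2.15 cells (Homo sapiens) for cytotoxicity, read by MTT assay (on this read-out higher numbers stand for lower toxicity in this test and lower numbers for higher toxicity in this test), compound 1 reaches only a limit, > 3100000 nM. Compound 2 likewise reaches only a limit in this assay, > 2590000 nM. For that reason a step that the two limits leave unreadable from compound 1 to compound 2, which is shown by the limit of > 2590000 nM in this assay, at which 1 of the 3 values shown sits, and (the limit of > 3100000 nM in this assay, at which 1 of the 3 values shown sits). Within the data shown here, compound 3 is the only one with a number in this assay, giving 828000 nM.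

Among the measured compounds shown here, the step from compound 3 to compound 4 in this assay is expected to be a 1.1-fold higher number from compound 3 to compound 4 (0.04 log units; within the scatter), resting on the one number that compound 3 gave, 828000 nM, since the earlier step cannot be read. Compound 4 is therefore expected to give 900000 nM, with a likely range from 350000 nM to 2500000 nM.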

Compound 4, half-maximal cytotoxic concentration: 874000 nM
The estimate for compound 4 lay 1.0-fold (0.01 log units) above the measured number; low and high end bracket the measured number.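

In this assay, going from 3-fluorophenyl to 3,4-difluorophenyl on the larger core gives a 1.1-fold higher number from compound 3 to compound 4 (0.02 log units; within the scatter), so on this core the added fluoro leaves the two compounds indistinguishable in this test. The matching step on the core of compound 1 cannot be read, because the pair on that core reaches only limits of the assay rather than numbers: the limit of > 2590000 nM in this assay, at which 1 of the 4 values shown sits. This leaves one readable result for the change, on one core, which shows what it does there but cannot show whether the outcome carries over from one core to the other.

The compounds shown change only one spot on the aromatic ring, and only by fluoro, so what a chloro group, a methoxy group or an amine would do at that place stays open. Also open, from the compounds shown here alone, is whether any of these groups would give a number distinct from compound 3 on the larger core.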